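This account rests on a few compounds, and the source may have more. Where it says the series, first, only, none or still open, it means among the compounds named here.

Of the compounds shown here, three built on one shared core have been tested in a functional assay on HL-60 cells (Homo sapiens) for antiproliferative activity, read by MTT assay, with a stated time of 48 h; on this read-out higher numbers stand for weaker inhibition and lower numbers for stronger inhibition. Compound 1 `CCN(CC)CCCCn1c(N)c(-c2nc3ccccc3[nH]2)c2nc(C#N)c(C#N)nc21` gives 460 nM. Compound 2 `CCN(CC)CCn1c(N)c(-c2nc3cc(Cl)ccc3[nH]2)c2nc(C#N)c(C#N)nc21` gives > 50000 nM, which is a limit of the assay and not a number. Compound 3 `CN(C)CCCn1c(N)c(-c2nc3cc(Cl)ccc3[nH]2)c2nc(C#N)c(C#N)nc21` gives 2930 nM, the higher of the two actual numbers, so it inhibits less strongly than compound 1.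

The next compound, compound 4 `CCN(CC)CCCCn1c(N)c(-c2nc3cc(Cl)ccc3[nH]2)c2nc(C#N)c(C#N)nc21`, alters the chain of compound 3: (diethylamino)methyl in place of dimethylamino on a saturated chain carbon, three bonds along the chain from an aromatic nitrogen. Read one bond further out, 3-(dimethylamino)propyl becomes 4-(diethylamino)butyl.

Among the compounds with values here, only one measured step bears directly on this chain, an at least 17-fold lower number from compound 2 to compound 3 (1.23 log units; beyond the scatter). That step is large and beyond the scatter, and it also ended on a longer chain, although it swapped diethylamino out, whereas the new change brings it back. It is therefore only a partial guide to direction, and its size is not expected to repeat. Compound 1 carries the same 4-(diethylamino)butyl chain and gives 460 nM, which points the same way.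

A moderate drop in this assay, beyond the scatter, is therefore expected, with an estimated step of a 4.2-fold lower number from compound 3 to compound 4 (0.62 log units; beyond the scatter). The estimate for compound 4 is 700 nM, with an expected range of 200 nM to 2500 nM.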

Compound 4, half-maximal inhibitory concentration: 820 nM
Compound 4: the middle estimate sits 1.2-fold (0.07 log units) below what was measured; the range from low to high includes it.
By their numbers in this assay, from the lowest: compounds 1 and 4 (each within the scatter of the next); then compound 3. At a limit, above all of these: compound 2.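

In this assay, the change to 4-(diethylamino)butyl gives a 3.6-fold lower number from compound 3 to compound 4 (0.55 log units; beyond the scatter), so this chain position still responds once the chain and the amine change together, though the shift is far smaller than the step that ended at compound 3. Within the data shown here, for the first time, a chloro can be read on its own, with the chain held the same: chloro in place of hydrogen on an aromatic carbon gives a 1.8-fold higher number from compound 1 to compound 4 (0.25 log units; within the scatter), so compound 1 and compound 4 cannot be told apart in this assay. With diethylamino kept at the chain end, lengthening the chain alone gives an at least 60-fold lower number from compound 2 to compound 4 (1.78 log units; beyond the scatter), a clear change whose true size stays unknown, as compound 2 supplies a limit and not a number: the limit of > 50000 nM in this assay, at which 1 of the 4 values shown sits.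

The compounds shown leave open how much of the step to compound 4 belongs to the longer chain and how much to the larger amine, which a 3-(diethylamino)propyl or 4-(dimethylamino)butyl chain on the same core would help to separate. Also open, from the compounds shown here alone, are a chain longer than butyl, a ring amine such as morpholine at the chain end, and whether chloro stays as silent on a shorter chain.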